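A few compounds are considered here, and "the series" means these few. Any claim that something is new, unique, unknown or untested is made for them only; others in the source may bear on it.

Compound 1, `O=C1OC(c2ccccc2)C(c2ccc(O)cc2)=C1O`, is the starting point. In an assay on blood for inhibition of Polyunsaturated fatty acid 5-lipoxygenase (Homo sapiens), tested at 100 uM (on this read-out higher numbers stand for a stronger effect at the one concentration tested and lower numbers for a weaker effect), compound 1 gives 18.6%, a modest effect at the single concentration tested. Within the data shown here, compound 2, `O=C1OC(c2cc(OCc3ccccc3)cc(OCc3ccccc3)c2)C(c2ccc(O)cc2)=C1O`, belongs to the same set, but in this assay compound 2 gives "not determined" (no result reported), so compound 1 stands alone as the only number so far, with nothing measured to compare it against. Compound 3, `O=C1OC(c2ccc(O)cc2)C(c2ccc(O)cc2)=C1O`, differs from compound 1 in one place: hydroxy in place of hydrogen on an aromatic carbon. Among the measured compounds shown here, no measured pair shows how such a change moves this read-out, so the direction rests on the change itself. The step is expected to be small and leaning upward, mostly within the scatter, at roughly a number 7.4 percentage points higher from compound 1 to compound 3 (within the scatter). The value expected for compound 3 in this assay is therefore 26%, most likely falling between 8% and 48%.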

Compound 3, a percentage reported as activity, at one concentration (the size of the read-out at that concentration, not a potency): 27.8%
For compound 3 the middle estimate is 1.8 percentage points below the measured one; low and high end bracket the measured number.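

Among these compounds, this is the first pair in the set that differs in one place, and it tests phenyl to 4-hydroxyphenyl on a six-membered aromatic ring of carbon only. In this assay, the change reads as a number 9.2 percentage points higher from compound 1 to compound 3 (within the scatter), so the two compounds cannot be told apart at the one concentration tested. Hydroxy is therefore tolerated at this ring carbon, at least in this one comparison, with no step beyond the usual scatter of repeated measurements. No independent measurement here helps explain this result.

One pair cannot show whether this ring position matters much for the read-out in general. As far as these compounds go, it remains open whether methoxy, an amine or a carboxylic acid on the same carbon would give a step clearly beyond the scatter.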